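A few compounds are considered here, and "the series" means these few. Any claim that something is new, unique, unknown or untested is made for them only; others in the source may bear on it.

Measured in a functional assay on NCI-H1975 cells (Homo sapiens) for inhibition, read by MTT assay, with a stated time of 72 h; a lower number here means a stronger inhibitor, a higher number a weaker inhibitor:
- Compound 1 `CCN1CCN(c2cc(C(F)(F)F)nc(SCc3ccc(C(F)(F)F)cc3)n2)CC1`: 15000 nM
- Compound 2 `FC(F)(F)c1ccc(CSc2nc(N3CCN(c4ccccc4)CC3)cc(C(F)(F)F)n2)cc1`: > 50000 nM, a limit of the assay and not a number

Compound 2 gives no number and stands at the limit of > 50000 nM in this assay, at which 1 of the 2 values shown sits. Compound 3 `FC(F)(F)c1ccc(CSc2nc(N3CCN(c4ccccn4)CC3)cc(C(F)(F)F)n2)cc1` carries pyridin-2-yl in place of phenyl on an amine nitrogen in a ring.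

Within the data shown here, one measured step bears on this place. It is an at least 3.3-fold higher number from compound 1 to compound 2 (0.52 log units; beyond the scatter), with phenyl entering in place of ethyl on that same amine nitrogen, and it lies beyond the scatter. That step does not involve pyridin-2-yl, so it sets no direct size for the change at hand. It does show that this position can move the read-out. Compound 1 stands at 15000 nM. Compound 3 is expected to remain a weak inhibitor in this assay, with at most a modest move towards lower numbers, and it may stay at the limit. The expected change is an at least 1.4-fold lower number from compound 2 to compound 3 (0.15 log units; that floor lies within the scatter). For compound 3 the estimated value is 35000 nM, with an expected range from 12000 nM to 80000 nM.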

Compound 3, half-maximal inhibitory concentration: 17400 nM
Estimate against measurement, compound 3: 2.0-fold (0.30 log units) above, and the stated range covers the measured number.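

In this assay, pyridin-2-yl in place of phenyl on the amine nitrogen in a ring gives an at least 2.8-fold lower number from compound 2 to compound 3 (0.45 log units; beyond the scatter) and so shows that this place responds to a change within the aromatic ring itself, not only to the swap of ethyl for phenyl seen earlier. An aromatic ring on this nitrogen is therefore not enough on its own to bring the read-out to the limit, since compound 3 also carries one. Set against the ethyl group, the result is a 1.2-fold higher number from compound 1 to compound 3 (0.06 log units; within the scatter) and puts pyridin-2-yl level with ethyl at this place, while compound 2 holds a limit of the assay and not a number, which makes the step from it a floor only: the limit of > 50000 nM in this assay, at which 1 of the 3 values shown sits.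

The compounds shown leave open whether the step depends on where the ring nitrogen sits or on its presence alone, a question that a pyridin-3-yl or a pyrimidin-2-yl group on the same amine nitrogen could address. They also leave open whether a methyl group, an acetyl group or a hydrogen at this place would move the read-out away from the level shared by compound 1 and compound 3.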